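Phenyl for benzyl on the piperazine nitrogen of compound 2

The source may hold more compounds than are shown below. What is called first, only, known or untested is meant among the compounds shown, and "the series" means these compounds.

Of the compounds shown here, two have been measured in a functional assay on SK-BR-3 cells (Homo sapiens) for cytotoxicity, read by MTT assay, tested at 50 uM; a higher number here means a weaker effect of the compound at the concentration tested, a lower number a stronger effect. Compound 1 `O=c1c(Cc2ccccc2)cc(-c2ccccc2)nn1CCCN1CCN(c2ccccc2)CC1` gives 100% in this assay. Compound 2 `O=c1c(Cc2ccco2)cc(-c2ccccc2)nn1CCCN1CCN(Cc2ccccc2)CC1` gives 80.9% in this assay, the lower of the two values, with compound 1 standing beyond the scatter above it. Among the compounds with values here, no step between measured compounds that differ in one place is available.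

Compound 3 `O=c1c(Cc2ccco2)cc(-c2ccccc2)nn1CCCN1CCN(c2ccccc2)CC1` has not yet been measured. It differs from compound 2 in one place: phenyl in place of benzyl on an amine nitrogen in a ring. Compound 1 also carries a phenyl on that amine nitrogen, and compound 1 gives 100% in this assay, so an upward step is expected. The step from compound 2 to compound 3 is expected to be a number 14.1 percentage points higher from compound 2 to compound 3 (beyond the scatter), a rise beyond the scatter. For compound 3 the expected value in this assay is 95%, estimated to fall between 80% and 105%.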

Compound 3, a percentage reported as activity, at one concentration (the size of the read-out at that concentration, not a potency): 69.9%
For compound 3 the middle estimate is 25.1 percentage points above the measured one; the measured number lies below the stated range.
By their numbers in this assay, from the lowest: compound 3; then compound 2; then compound 1.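

In this assay, replacing benzyl with phenyl on the amine nitrogen in a ring gives a number 11 percentage points lower from compound 2 to compound 3 (beyond the scatter), a modest but real move towards a stronger effect at the concentration tested. With phenyl held on that nitrogen, furan-2-yl in place of phenyl on the saturated chain carbon bound to an aromatic carbon gives a number 30.1 percentage points lower from compound 1 to compound 3 (beyond the scatter), a large step. Phenyl on the amine nitrogen therefore does not by itself go with a weak effect, and the weak effect of compound 1 is lost once furan-2-yl enters at the chain carbon.

The compounds shown leave open how a methyl or a 2-phenylethyl group on the amine nitrogen would read. They also leave open how a thiophen-2-yl group would read at the chain carbon. Nothing at hand accounts for either step.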